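The source may hold more compounds than are shown below. What is called first, only, known or untested is meant among the compounds shown, and "the series" means these compounds.

Measured so far in an ADME assay on MRC5 cells (Homo sapiens) for inhibition, with a stated time of 72 h; on this read-out higher numbers stand for an effect only at larger amounts of compound and lower numbers for an effect already at smaller amounts:
Compound 1, `CO[C@H]1CC[C@H](NC(=O)c2n[nH]cc2NC(=O)c2cc(Cl)cc(Cl)c2)CC1`: 13000 nM
Compound 2, `COc1cccc(OC)c1C(=O)Nc1c[nH]nc1C(=O)NCc1ccccn1`: > 50000 nM, a limit of the assay, not a number
Compound 3, `CO[C@H]1CC[C@H](NC(=O)c2n[nH]cc2NC(=O)c2ccc(F)cc2F)CC1`: 11000 nM

Going by these compounds, compound 2 therefore stands at the limit of > 50000 nM in this assay, at which 1 of the 3 values shown sits, and its true value is unknown. Among the measured compounds shown here, the only measured step, a 1.2-fold lower number from compound 1 to compound 3 (0.07 log units; within the scatter), concerns a change on a carbonyl carbon of the core of compound 1 and does not touch the amide-type nitrogen, so no measured step bears on the change to compound 4, `COc1cccc(OC)c1C(=O)Nc1c[nH]nc1C(=O)NC1CCCCC1`. That change is cyclohexyl in place of (pyridin-2-yl)methyl on an amide-type nitrogen. With nothing to go on, the step that the limit leaves unreadable from compound 2 to compound 4 is expected to remain within the scatter. Compound 4 is accordingly estimated at 60000 nM, between 25000 nM and 150000 nM, and most likely will again be reported only as a limit.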

Compound 4, half-maximal effective concentration: 35000 nM
Estimate against measurement, compound 4: 1.7-fold (0.23 log units) above; measured number inside the range.
By their numbers in this assay, from the lowest: compounds 3 and 1 (each within the scatter of the next); then compound 4. At a limit, above all of these: compound 2.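

In this assay, cyclohexyl in place of (pyridin-2-yl)methyl on an amide-type nitrogen gives an at least 1.4-fold lower number from compound 2 to compound 4 (0.15 log units; that floor lies within the scatter). Among the compounds shown here, compound 2 stands at a limit and not at a number, so the true size of this step stays unknown: the limit of > 50000 nM in this assay, at which 1 of the 4 values shown sits. Unlike compound 2, compound 4 gives a measured number with this change, which provides the first reading on this amide-type nitrogen that is not a limit.

Going by these compounds, how a benzyl group or a simple butyl chain on this nitrogen would read remains open. So does whether a basic amine there would leave the number within the scatter of compound 4.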